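The source may report more compounds than this note shows. Statements on the series, on what has been measured and on what is new or still open speak of the compounds shown alone.

Measured in an ADME assay on MDCK-II cells (Canis lupus familiaris) for permeability; on this read-out higher numbers stand for higher permeability and lower numbers for lower permeability:
compound 1 `CC(C)Oc1cc(Oc2ccc(S(C)(=O)=O)cc2)cc(-c2cccc(=O)[nH]2)c1`: 18 10^-6 cm/s
compound 2 `CC(C)Oc1cc(Oc2ccc(S(C)(=O)=O)cc2)cc(-c2cncc(=O)[nH]2)c1`: 94 10^-6 cm/s

Compound 1 holds the lower of the two numbers, at 18 10^-6 cm/s, and compound 2 gives 94 10^-6 cm/s. Compound 3 `Cc1cnc(-c2cc(Oc3ccc(S(C)(=O)=O)cc3)cc(OC(C)C)c2)[nH]c1=O` has not yet been measured. Its change from compound 1 is a group of 8 heavy atoms (5 carbon, 2 nitrogen, 1 oxygen; one six-membered aromatic ring with 2 hetero atoms) in place of a group of 7 heavy atoms (5 carbon, 1 nitrogen, 1 oxygen; one six-membered aromatic ring with 1 hetero atom), on an aromatic carbon, on an aromatic carbon of a six-membered aromatic ring of carbon only, meta to a large group and meta to an isopropoxy group.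

For the measured compounds named here, only one measured step bears on this change: a 5.2-fold higher number from compound 1 to compound 2 (0.72 log units; beyond the scatter). There too, a six-membered aromatic ring with 1 hetero atom gives way to one with 2 hetero atoms, at the same place. However, the group entering in compound 3 is not the group found in compound 2, and no measured pair separates the two. Going by the values given here, a rise is therefore expected, smaller than the single step seen with compound 2 and with wide uncertainty. The expected step is a 2.8-fold higher number from compound 1 to compound 3 (0.44 log units; beyond the scatter). In this assay the estimate for compound 3 is 50 10^-6 cm/s, with an expected range of 18 10^-6 cm/s to 130 10^-6 cm/s.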

Compound 3, apparent permeability: 17 10^-6 cm/s
Beside the measured number, compound 3's estimate is 2.9-fold (0.47 log units) above it, and the stated range ends above it.
By their numbers in this assay, from the lowest: compounds 3 and 1 (each within the scatter of the next); then compound 2.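

In this assay, a six-membered aromatic ring with 2 hetero atoms at this place does not by itself set a compound apart from compound 1, as a 1.1-fold lower number from compound 1 to compound 3 (0.02 log units; within the scatter) shows for the group of 8 heavy atoms. The comparison between the two groups that both hold such a ring is the new reading: a 5.5-fold lower number from compound 2 to compound 3 (0.74 log units; beyond the scatter) marks a step beyond the scatter, so across these three compounds the hetero atom count of the ring does not decide the number in this assay, and the high value stays with compound 2 alone. No measurement at hand accounts for the gap between the group of 7 heavy atoms and the group of 8 heavy atoms.

On these data alone, whether the step from compound 2 to compound 3 is specific to the extra carbon of the entering group remains open, since a fluorine, a chlorine or a methoxy group on that ring would be needed to test it. Also open, as far as these compounds go, is whether the same steps hold when the isopropoxy group on the core is replaced, for example by an ethoxy or a cyclopropoxy group.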